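A few compounds are considered here, and "the series" means these few. Any claim that something is new, unique, unknown or untested is made for them only; others in the source may bear on it.

Measured so far:
compound 1 `Cc1occc1-c1nnc(SCC(=O)Nc2ccc(F)c(Cl)c2)n1Cc1ccco1` — 39.8 nM
compound 2 `Cc1occc1-c1nnc(SCC(=O)Nc2cccc(F)c2)n1Cc1ccco1` — 501 nM

In a functional assay on CHO cells for antagonist activity at Orexin receptor type 2 (Homo sapiens), read by FLIPR and calcium flux (on this read-out lower numbers stand for stronger inhibition and higher numbers for weaker inhibition), compound 1 stands at the lowest of the two numbers, and the step of a 13-fold higher number from compound 1 to compound 2 (1.10 log units; beyond the scatter) is large. Compound 3 `CC(=O)c1cccc(NC(=O)CSc2nnc(-c3ccoc3C)n2Cc2ccco2)c1` carries the change (3-acetylphenyl in place of 3-chloro-4-fluorophenyl on an amide-type nitrogen). Going by the values given here, only that step bears on it: losing the chlorine, as from compound 1 to compound 2, cost a lot, and the 3-acetylphenyl keeps a group at the same place while dropping both halogens. A weakening is therefore expected for compound 3, smaller than that step, and its estimated value is 160 nM (range 40 nM to 630 nM), meaning a 4.0-fold higher number from compound 1 to compound 3 (0.60 log units; beyond the scatter).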

Compound 3, inhibition constant: 316 nM
For compound 3 the middle estimate is 2.0-fold (0.30 log units) below the measured one; the measured number falls inside the stated range.
By their numbers in this assay, from the lowest: compound 1; then compounds 3 and 2 (each within the scatter of the next).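

In this assay, 3-acetylphenyl on the amide-type nitrogen does not match 3-chloro-4-fluorophenyl (a 7.9-fold higher number from compound 1 to compound 3 (0.90 log units; beyond the scatter)), so a second replacement, one carrying no halogen, also gives a number beyond the scatter of compound 1. Acetyl in place of fluoro gives no step beyond the scatter (a 1.6-fold lower number from compound 2 to compound 3 (0.20 log units; within the scatter)), so these two groups cannot be told apart here, although only acetyl brings a hydrogen-bond acceptor. Nothing available accounts for these steps. Open, as far as these compounds go, is whether chlorine alone would hold the number of compound 1, as a 3-chlorophenyl group would show. Also open, from the compounds shown here alone, is how an amine or a carboxylic acid would read on this ring.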